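The source may report more compounds than this note shows. Statements on the series, on what has been measured and on what is new or still open speak of the compounds shown alone.

In a functional assay on PC-3 cells (Homo sapiens) for antiproliferative activity, read by MTT assay, with a stated time of 48 h (a higher number here means a weaker inhibitor, a lower number a stronger inhibitor), compound 1 `Cc1cccc(NC(=O)Nc2nnc(Sc3ncnc4scc(-c5ccncc5)c34)s2)c1` gives 5200 nM, compound 2 `O=C(Nc1cccc(Cl)c1)Nc1nnc(Sc2ncnc3scc(-c4ccncc4)c23)s1` gives 8000 nM, and compound 3 `COc1cccc(NC(=O)Nc2nnc(Sc3ncnc4scc(-c5ccncc5)c34)s2)c1` gives 6800 nM. Compound 3 thus stands second highest of these three numbers, yet the steps of a 1.3-fold higher number from compound 1 to compound 3 (0.12 log units; within the scatter) and a 1.2-fold lower number from compound 2 to compound 3 (0.07 log units; within the scatter) both lie within the scatter. Compound 4 `O=C(Nc1cccc(F)c1)Nc1nnc(Sc2ncnc3scc(-c4ccncc4)c23)s1` differs from compound 3 by fluoro in place of methoxy on an aromatic carbon. The measured steps that bear on an exchange at this same aromatic carbon, a 1.5-fold higher number from compound 1 to compound 2 (0.19 log units; within the scatter) and a 1.3-fold higher number from compound 1 to compound 3 (0.12 log units; within the scatter), stayed within the scatter, so the expected step is a 1.0-fold lower number from compound 3 to compound 4 (0.02 log units; within the scatter), nothing beyond the scatter in either direction. In this assay compound 4 is therefore estimated at 6500 nM, within a range of 3000 nM to 14000 nM.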

Compound 4, half-maximal inhibitory concentration: 6600 nM
Compound 4: middle estimate off by 1.0-fold (0.01 log units), on the low side; measured number inside the range.
By their numbers in this assay, from the lowest: compounds 1, 4, 3 and 2 (each within the scatter of the next).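

Fluoro joins methyl, chloro and methoxy on this aromatic carbon in this assay with a 1.0-fold lower number from compound 3 to compound 4 (0.01 log units; within the scatter) and with a 1.2-fold lower number from compound 2 to compound 4 (0.08 log units; within the scatter) and with a 1.3-fold higher number from compound 1 to compound 4 (0.10 log units; within the scatter) as its steps, so all four groups lie within the scatter of one another. Even exchanging methoxy, with two heavy atoms and a hydrogen-bond acceptor, for fluoro, with one heavy atom and no acceptor, gives no readable change. No evidence is available to explain this flat result. The compounds shown leave open whether an amine, a carboxylic acid or a longer chain on this carbon would move the number beyond the scatter.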